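A few compounds are considered here, and "the series" means these few. Any claim that something is new, unique, unknown or untested is made for them only; others in the source may bear on it.

The study concerns a small set of compounds built on one shared core. Compound 1 `CC(=O)N1N=C(Nc2nc3ccccc3s2)CC1c1ccc(Cl)cc1` and compound 2 `CC(=O)N1N=C(Nc2nc3ccc(Cl)cc3s2)CC1OC1=CC=C1` belong to the set, but in a functional assay on the whole organism (strain albino) with Mus musculus as the target, with a stated time of 0.5 h (a higher number here means that more compound is needed for the effect, a lower number that less compound is needed), compound 1 gives "not determined" (no result reported) and compound 2 gives "not determined" (no result reported), so neither contributes a number. Among the compounds with values here, compound 3 `CC(=O)N1N=C(Nc2nc3ccc(C)cc3s2)CC1c1ccc(Cl)cc1` is the only member with a result: in this assay compound 3 gives 27.5 umol/kg, which therefore stands alone as the sole reference point, with no second value to rank it against.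

Compound 4 `CC(=O)N1N=C(Nc2nc3ccc(Cl)cc3s2)CC1c1ccc(Cl)cc1` differs from compound 3 in one place: chloro in place of methyl on an aromatic carbon. Within the data shown here, no pair of measured compounds shows this change, so there is no recorded step to lean on. The swap exchanges one heavy atom for one heavy atom, with no ring, no hydrogen-bond donor or acceptor and no charge added or lost.

On that basis the account expects no step beyond the usual scatter from compound 3 to compound 4, that is, an expected 1.1-fold lower number from compound 3 to compound 4 (0.04 log units; within the scatter). For compound 4 in this assay the estimated dose is 25 umol/kg, with an expected range from 12 umol/kg to 55 umol/kg.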

Compound 4, dose for half-maximal effect: 81.5 umol/kg
Estimate against measurement, compound 4: 3.3-fold (0.51 log units) below; the measured number lies above the stated range.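

The position on an aromatic carbon of the six-membered aromatic ring of carbon only now proves sensitive to what it carries: in this assay, chloro in place of methyl gives a 3.0-fold higher number from compound 3 to compound 4 (0.47 log units; beyond the scatter), a modest step but one that lies beyond the scatter. Methyl and chloro each count one heavy atom, with no hydrogen-bond donor or acceptor and no net charge, yet they are not interchangeable here, and compound 3 needs less compound for the effect than compound 4. No measurement shown explains this step.

This single pair gives a direction for these two groups only and sets no trend for the position. On these data alone, whether a methoxy group or an amine at the same place would fall nearer compound 3 or compound 4, or outside both, remains open.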